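Replacing cyano with 4-chlorophenyl in compound 2

A few compounds are considered here, and "the series" means these few. Any claim that something is new, unique, unknown or untested is made for them only; others in the source may bear on it.

Values so far in an ADME assay on BJ cells (Homo sapiens) for cytotoxicity, with a stated time of 72 h; on this read-out lower numbers stand for an effect already at smaller amounts and higher numbers for an effect only at larger amounts of compound
compound 1 `C=C[C@@](C)(/C=C/c1ccc(O)cc1)CC/C=C(C)/C=C/C(=O)OCC` gives > 36600 nM as a limit
compound 2 `C=C[C@@](C)(/C=C/c1ccc(O)c(/C=C/C#N)c1)CCC=C(C)C` gives > 36600 nM as a limit
compound 3 `C=C[C@@](C)(/C=C/c1ccc(O)c(/C=C/C(=O)NCc2ccc(C(F)(F)F)cc2)c1)CCC=C(C)C` gives > 36600 nM as a limit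

None of these entries is an exact number, since each one is a limit of the assay. Compound 2 stands with the other two, reported only as the limit > 36600 nM and not as a measured value. Among the measured compounds shown here, the record so far comes down to the limit of > 36600 nM in this assay, at which 3 of the 3 values shown sit, and so offers no measured step between compounds.

Compound 4 `C=C[C@@](C)(/C=C/c1ccc(O)c(/C=C/c2ccc(Cl)cc2)c1)CCC=C(C)C` has not yet been measured. It differs from compound 2 by one change 4-chlorophenyl in place of cyano on a double-bonded chain carbon bound to a double-bonded chain carbon which puts 4-chlorophenyl in place of cyano on a double-bonded chain carbon bound to a double-bonded chain carbon. Read one bond further out, 2-cyanoethenyl becomes 2-(4-chlorophenyl)ethenyl.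

Compound 3 also carries a larger group in place of the cyano, and it gives > 36600 nM as a limit in this assay as well. The expected change is an at least 1.2-fold lower number from compound 2 to compound 4 (0.08 log units; that floor lies within the scatter) and this estimate amounts to no step beyond the usual scatter, with a further limit being the likeliest report. Compound 4 is estimated at 30000 nM within an expected range of 12000 nM to 60000 nM on this read-out.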

Compound 4, half-maximal effective concentration: > 36600 nM
Compound 4: only a limit was reported; the forecaster's own chance of this, stated with the estimate: 65%; at least 1.2-fold (0.08 log units) between middle value and limit.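

Compound 2 and compound 4 are both reported only as limits, so no step between them can be read in this assay: the limit of > 36600 nM in this assay, at which 4 of the 4 values shown sit.

The compounds shown leave open at what concentration any of them would reach a half-maximal effect on these cells, and whether 4-chlorophenyl in place of cyano alters that concentration at all.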